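Swapping the aryl group on the amide of compound 2

The compounds below may be only part of what the source reports. "The series", "measured", "known", "first", "only" and "open" are said of these compounds alone.

Compound 2 `C=C(CC)C(=O)c1ccc(OCC(=O)Nc2ccc(O)c(Cl)c2)c(Cl)c1Cl` gives 5500 nM in a functional assay on CLL cells (Homo sapiens) for cytotoxicity, read by MTT assay, with a stated time of 48 h (a higher number here means that more compound is needed for the effect, a lower number that less compound is needed), and stands at the lowest of the three numbers, though its neighbours sit close: compound 1 `C=C(CC)C(=O)c1ccc(OCC(=O)Nc2ccc(O)c([N+](=O)[O-])c2)c(Cl)c1Cl` gives 7400 nM and compound 3 `C=C(CC)C(=O)c1ccc(OCC(=O)NC2CCN(CC(=O)OC)CC2)c(Cl)c1Cl` gives 10600 nM, both within the scatter of compound 2. Compound 4 `C=C(CC)C(=O)c1ccc(OCC(=O)Nc2ccc(C(N)=O)cc2)c(Cl)c1Cl` carries 4-carbamoylphenyl in place of 3-chloro-4-hydroxyphenyl on an amide-type nitrogen. For the measured compounds named here, the only comparable step, a 1.3-fold lower number from compound 1 to compound 2 (0.13 log units; within the scatter), also changed the aryl group on that amide nitrogen and stayed within the scatter; compound 3, with a non-aromatic group there, likewise lies within the scatter of compound 2. No step beyond the scatter is therefore expected in this assay, and the step of a 1.3-fold higher number from compound 2 to compound 4 (0.10 log units; within the scatter) is an estimate close to no change. Compound 4 is expected to give about 7000 nM, between 3000 nM and 16000 nM.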

Compound 4, half-maximal effective concentration: 3700 nM
Beside the measured number, compound 4's estimate is 1.9-fold (0.28 log units) above it; low and high end bracket the measured number.
By their numbers in this assay, from the lowest: compounds 4, 2, 1 and 3 (each within the scatter of the next, the first and the last beyond it).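

Swapping the whole 3-chloro-4-hydroxyphenyl for 4-carbamoylphenyl on the amide-type nitrogen gives, in this assay, a 1.5-fold lower number from compound 2 to compound 4 (0.17 log units; within the scatter). The earlier aromatic step exchanged only nitro for chloro and kept the hydroxyl, whereas here neither the chlorine nor the hydroxyl remains, and the number still stays within the scatter. No supporting data are available to explain this result. As far as these compounds go, whether a carboxylic acid or an amine on this aromatic ring would also stay within the scatter remains open, as does whether any group on this nitrogen can move the number beyond it.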